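A few compounds are considered here, and "the series" means these few. Any claim that something is new, unique, unknown or untested is made for them only; others in the source may bear on it.

In a functional assay on the whole organism for inhibition, with Rattus norvegicus as the target (a higher number here means that more compound is needed for the effect, a lower number that less compound is needed), compound 1 `CC(C)c1ccc(OC(C)(Cc2ccc(Cl)cc2)C(=O)O)cc1` gives 1 mg/kg; 1 mg/kg; 1 mg/kg (3 entries) and compound 2 `CC(C)c1ccc(OC(C)(Cc2cccc(-c3ccccc3)c2)C(=O)O)cc1` gives 0.5 mg/kg. Compound 3 `CC(C)c1ccc(OC(C)(Cc2ccc(Cl)cc2)C(=O)NS(=O)(=O)C(F)(F)F)cc1` gives 5 mg/kg, the highest number of the three and beyond the scatter from compound 2. Compound 4 `COc1ccc(S(=O)(=O)NC(=O)C(C)(Cc2ccc(Cl)cc2)Oc2ccc(C(C)C)cc2)cc1` has 4-methoxyphenyl in place of trifluoromethyl on a sulfonyl sulfur. Among the measured compounds shown here, no measured pair shows this change, and compound 3 is the only measured compound with a sulfonyl group, so the expectation stays anchored on compound 3 at 5 mg/kg. The expected step of a 1.7-fold lower number from compound 3 to compound 4 (0.22 log units; within the scatter) is slightly downward in this assay and does not go beyond the scatter. For compound 4 the estimated value is 3 mg/kg, with an expected range of 0.8 mg/kg to 10 mg/kg.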

Compound 4, dose for half-maximal effect: > 10 mg/kg
Compound 4: only a limit was reported (the forecaster's own chance of this, stated with the estimate: 10%); middle value at least 3.3-fold (0.52 log units) away from the limit.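

Putting 4-methoxyphenyl in place of trifluoromethyl on the sulfonyl sulfur gives an at least 2.0-fold higher number from compound 3 to compound 4 (0.30 log units; that floor lies within the scatter) in this assay. For compound 4, > 10 mg/kg is a limit of the assay and not a number, so the true size of this step cannot be read. Even so, nothing here shows the six-membered aromatic ring at this position lowering the number.

The compounds shown leave open how a methyl or an unsubstituted phenyl on the sulfonyl sulfur would read in this assay. Whether the ring or its methoxy group matters more therefore remains unsettled.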